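The source may hold more compounds than are shown below. What is called first, only, known or untested is meant among the compounds shown, and "the series" means these compounds.

In an assay on HEK293 cells for agonist activity at transient receptor potential cation channel subfamily M member 8 (Homo sapiens), read by fluorescence and calcium flux, with a stated time of 15 min (on this read-out lower numbers stand for an effect already at smaller amounts and higher numbers for an effect only at larger amounts of compound), compound 1 `CCC(C)N(Cc1cccs1)C(=O)COc1ccc(C)cc1` gives 2000 nM, and compound 2 `Cc1ccc(OCC(=O)N(Cc2cccs2)c2nccn2C)cc1` gives 1790 nM; the step of a 1.1-fold lower number from compound 1 to compound 2 (0.05 log units; within the scatter) means these two numbers are not distinguishable, so compound 2 stands on level ground with compound 1. Compound 3 `Cc1ccc(OCC(=O)N(CCCO)Cc2cccs2)cc1` differs from compound 2 by 3-hydroxypropyl in place of 1-methyl-1H-imidazol-2-yl on an amide-type nitrogen. Within the data shown here, the only step that bears on this is the swap at the same nitrogen from compound 1 to compound 2, which stayed within the scatter, so in this assay no step beyond the scatter is expected here either. Compound 3 is therefore estimated at 2000 nM, between 700 nM and 6000 nM, a step of a 1.1-fold higher number from compound 2 to compound 3 (0.05 log units; within the scatter).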

Compound 3, half-maximal effective concentration: 3000 nM
The estimate for compound 3 lay 1.5-fold (0.18 log units) below the measured number, and the stated range covers the measured number.
By their numbers in this assay, from the lowest: compounds 2, 1 and 3 (each within the scatter of the next).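

At this amide-type nitrogen, three quite different groups now read alike in this assay. Replacing the aromatic 1-methyl-1H-imidazol-2-yl with the ringless 3-hydroxypropyl, which carries a hydrogen-bond donor, gives a 1.7-fold higher number from compound 2 to compound 3 (0.22 log units; within the scatter), and replacing sec-butyl with 3-hydroxypropyl gives a 1.5-fold higher number from compound 1 to compound 3 (0.18 log units; within the scatter), so neither a ring nor a branched carbon chain is needed here for this level of agonist activity. No measurement shown offers an explanation for this sameness. From the compounds shown here alone, whether an amine, a carboxylic acid or a longer chain on this nitrogen would stay at the same level remains open.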